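Changing the Halophenyl Group on Compound 1

This account rests on a few compounds, and the source may have more. Where it says the series, first, only, none or still open, it means among the compounds named here.

Compound 1, `C=C1[C@@H](OC(C)=O)C[C@@H]2[C@](C)(COC=O)[C@H](OC(C)=O)CC[C@@]2(C)[C@@H]1C[C@@H](Nc1cccc(F)c1)C1=CCOC1=O`, gives 14100 nM in a functional assay on MCF7 cells (Homo sapiens) for cytotoxicity, read by sulforhodamine B assay; a lower number here means a stronger inhibitor, a higher number a weaker inhibitor.
Compound 2, `C=C1CC[C@@H]2[C@](C)(CO[Si](C)(C)C(C)(C)C)[C@H](OC(C)=O)CC[C@@]2(C)[C@@H]1C/C=C1/C(=O)OC[C@H]1OC(C)=O`, gives 4840 nM in this assay.
Compound 3, `C=C1[C@@H](OC(C)=O)C[C@@H]2[C@](C)(CO[Si](C)(C)C(C)(C)C)[C@H](OC(C)=O)CC[C@@]2(C)[C@@H]1C/C=C1/C(=O)OC[C@H]1OC(C)=O`, gives 4540 nM in this assay.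

Among these three, compound 1 carries the highest number, which in this assay means the weakest inhibition: compound 2 and compound 3 both sit at lower numbers, and both gaps lie beyond the usual scatter. Compound 4, `C=C1[C@@H](OC(C)=O)C[C@@H]2[C@](C)(COC=O)[C@H](OC(C)=O)CC[C@@]2(C)[C@@H]1C[C@@H](Nc1ccc(Br)cc1)C1=CCOC1=O`, has not yet been measured. It differs from compound 1 in one place: 4-bromophenyl in place of 3-fluorophenyl on an amine nitrogen.

Among the compounds with values here, the only measured step among the known compounds is a 1.1-fold lower number from compound 2 to compound 3 (0.03 log units; within the scatter), an acetoxy on a saturated ring carbon; it does not touch the aryl amine part of the molecule and so says nothing direct about the change from compound 1 to compound 4. Within the data shown here, no measured pair shows what exchanging one halophenyl group for another does here. Without such a guide, the plainest expectation is that compound 4 stays close to compound 1, with the step of a 1.0-fold lower number from compound 1 to compound 4 (0.00 log units; within the scatter) expected to lie within the scatter, while the range must be kept wide to allow for either direction. Compound 4 is therefore estimated at 14000 nM, between 5000 nM and 40000 nM.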

Compound 4, half-maximal inhibitory concentration: 11400 nM
Beside the measured number, compound 4's estimate is 1.2-fold (0.09 log units) above it; the measured number falls inside the stated range.
By their numbers in this assay, from the lowest: compounds 3 and 2 (each within the scatter of the next); then compounds 4 and 1 (each within the scatter of the next).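

Within the data shown here, exchanging 3-fluorophenyl for 4-bromophenyl on the amine nitrogen gives a 1.2-fold lower number from compound 1 to compound 4 (0.09 log units; within the scatter) in this assay, the first measured step that touches this part of the molecule. The two halophenyl groups therefore read alike here, even though the halogen and the number in the group's name both change in this one step, and the same core and the same amine link are kept. No separate measurement bears on why these two groups give matching numbers.

With two features changing together, this single pair cannot show what the halogen or its place on the ring would do alone, and the result speaks only for these two halophenyl groups, not for aryl groups in general. As far as these compounds go, what happens with an unsubstituted phenyl, a saturated cyclohexyl group or a small methyl on the amine nitrogen remains open, as does whether any such replacement could bring compound 4 from 11400 nM down to the lower numbers seen for other compounds in this set.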